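This account rests on a few compounds, and the source may have more. Where it says the series, first, only, none or still open, it means among the compounds named here.

Measured so far:
- compound 1 `CNC(=O)N1CCCc2ccc(NC(=O)c3ccc(-c4ccccc4)cc3)cc21` gives 74.3% in a functional assay on MV4-11 cells (Homo sapiens) for antiproliferative activity, with a stated time of 6 days, tested at 6.25 uM; on this read-out lower numbers stand for a weaker effect and higher numbers for a stronger effect at the one concentration tested
- compound 2 `CNC(=O)N1CCCc2ccc(NC(=O)c3ccc(-c4ccncc4)cc3)cc21` gives 88.7% in this assay

Among the compounds with values here, compound 2 holds the higher of the two numbers; its only neighbour, compound 1, sits lower by a gap beyond the scatter. Within the data shown here, the single step measured here, a number 14.4 percentage points higher from compound 1 to compound 2 (beyond the scatter), came with pyridin-4-yl in place of phenyl on an aromatic carbon. Compound 3 `CNC(=O)N1CCCc2ccc(NC(=O)c3ccc(-c4ccn(S(C)(=O)=O)n4)cc3)cc21` has not yet been measured. It differs from compound 2 in one place: 1-(methylsulfonyl)-1H-pyrazol-3-yl in place of pyridin-4-yl on an aromatic carbon. The measured step bears on this only loosely: again one aromatic ring replaces another para to a large group, but the entering ring is a different one carrying a methylsulfonyl, and nothing measured shows how such a ring behaves in this assay. The expectation is therefore no step beyond the scatter, with a slight lean downward. Compound 3 is estimated to give 80% in this assay, within 55% to 95%. That estimate means an expected step of a number 8.7 percentage points lower from compound 2 to compound 3 (within the scatter).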

Compound 3, a percentage reported as inhibition, at one concentration (the size of the read-out at that concentration, not a potency): 57.2%
Beside the measured number, compound 3's estimate is 22.8 percentage points above it; measured number inside the range.
By their numbers in this assay, from the lowest: compound 3; then compound 1; then compound 2.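

At this position, para to a large group, not every aromatic ring is tolerated equally: in this assay, 1-(methylsulfonyl)-1H-pyrazol-3-yl in place of pyridin-4-yl brings a number 31.5 percentage points lower from compound 2 to compound 3 (beyond the scatter) and is the largest step seen so far. The same ring also falls short of plain phenyl, with a number 17.1 percentage points lower from compound 1 to compound 3 (beyond the scatter) for that swap, so changing this ring can move the number down as well as up, and the loss is more than the absence of what pyridin-4-yl added. Nothing available explains this drop.

The compounds shown leave open whether the drop follows the five-membered ring or the methylsulfonyl on it, as the two enter together in a single change. A 1-methyl-1H-pyrazol-3-yl group, with a simple methyl on the same ring, would help tell those two apart.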